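Thiophene for phenyl at the pyrazole-bearing aryl position

The source may report more compounds than this note shows. Statements on the series, on what has been measured and on what is new or still open speak of the compounds shown alone.

Compounds measured so far:
compound 1, `NS(=O)(=O)c1ccc2nc(-n3nc(C(F)(F)F)cc3-c3ccc(Br)cc3)sc2c1`, 56%
compound 2, `NS(=O)(=O)c1ccc2nc(-n3nc(C(F)(F)F)cc3-c3ccco3)sc2c1`, 46%
compound 3, `NS(=O)(=O)c1ccc2nc(-n3nc(C(F)(F)F)cc3-c3ccccc3)sc2c1`, 48%

In a functional assay on the whole organism (strain Wistar albino) for inhibition, with Rattus norvegicus as the target, read by paw edema, with stated times of 30 min and 2 h, at a dose of 50 mg/kg by the oral route (on this read-out higher numbers stand for more inhibition at the one dose given (going by the name of the read-out) and lower numbers for less inhibition), compound 3 gives 48%, which is the second highest of the three numbers. Its nearest neighbour is compound 2: the step of a number 2 percentage points higher from compound 2 to compound 3 (within the scatter) lies within the scatter. The furthest is compound 1, and the step of a number 8 percentage points lower from compound 1 to compound 3 (within the scatter) also lies within the scatter, so nothing separates compound 3 from either of the others in this assay beyond ordinary variation.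

Compound 4, `NS(=O)(=O)c1ccc2nc(-n3nc(C(F)(F)F)cc3-c3cccs3)sc2c1`, differs from compound 3 in one place: thiophen-2-yl in place of phenyl on an aromatic carbon. The step that bears on it most directly is the exchange of a five-membered aromatic ring with one hetero atom for phenyl, seen from compound 2 to compound 3, where the step of a number 2 percentage points higher from compound 2 to compound 3 (within the scatter) was within the scatter. The other recorded exchanges, a number 10 percentage points lower from compound 1 to compound 2 (within the scatter) and a number 8 percentage points lower from compound 1 to compound 3 (within the scatter), were likewise within the scatter. Because a number 2 percentage points higher from compound 2 to compound 3 (within the scatter) was so small, the step into compound 4 is expected to be small as well, in no clear direction: a number 1 percentage points lower from compound 3 to compound 4 (within the scatter). Compound 4 is therefore estimated at 47%, within a range from 37% to 57% in this assay.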

Compound 4, a percentage reported as inhibition, in the whole organism at one dose (the size of the read-out at that dose, not a potency): 26%
Estimate against measurement, compound 4: 21 percentage points above; the whole stated range lies above it.
By their numbers in this assay, from the lowest: compound 4; then compounds 2, 3 and 1 (each within the scatter of the next).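

Until compound 4, this aromatic carbon of the five-membered ring with 2 nitrogen had carried 4-bromophenyl, phenyl and furan-2-yl with no step beyond the scatter, but in this assay the exchange of phenyl for thiophen-2-yl gives a number 22 percentage points lower from compound 3 to compound 4 (beyond the scatter), so the position is not indifferent to the ring placed on it. Ring size and the count of hetero atoms do not by themselves set the outcome, since furan-2-yl and thiophen-2-yl are both five-membered aromatic rings with 1 hetero atom, yet the exchange between them gives a number 20 percentage points lower from compound 2 to compound 4 (beyond the scatter), and the comparison with the 4-bromophenyl compound gives a number 30 percentage points lower from compound 1 to compound 4 (beyond the scatter), which leaves compound 4 the lowest of the four. The data shown offer no measurement that accounts for this drop.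

The compounds shown leave open whether the drop belongs to thiophene as such or to its point of attachment, which thiophen-3-yl would address, and whether a 5-bromothiophen-2-yl group would behave like thiophen-2-yl. They also leave open how a pyridin-2-yl ring would fare here, and, with a single dose in this assay, how any of these differences would appear at other doses.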